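Ester for Amine on the Phenyl Ring: an Expected Gain

The compounds below may be only part of what the source reports. "The series", "measured", "known", "first", "only" and "open" are said of these compounds alone.

Compound 1 `Nc1ccccc1-c1cnc(C(=O)CCCCCCc2ccccc2)o1` gives 750 nM in an assay (Rattus norvegicus) for inhibition of Fatty-acid amide hydrolase 1 (Homo sapiens); on this read-out lower numbers stand for stronger inhibition and higher numbers for weaker inhibition. Compound 2 `COC(=O)c1ccccc1-c1cnc(C(=O)CCCCCCc2ccccc2)o1` gives 60 nM in this assay. Compound 3 `Nc1ccc(-c2cnc(C(=O)CCCCCCc3ccccc3)o2)cc1` gives 90 nM in this assay.

The three share a core and differ only in the group on the phenyl ring and where that group sits. From compound 1 to compound 2 the change is methoxycarbonyl in place of amino on an aromatic carbon, and it brings a 13-fold lower number from compound 1 to compound 2 (1.10 log units; beyond the scatter). From compound 1 to compound 3 the difference is 4-aminophenyl in place of 2-aminophenyl on an aromatic carbon, giving an 8.3-fold lower number from compound 1 to compound 3 (0.92 log units; beyond the scatter). Compound 2 and compound 3 lie within the scatter of each other, so no order between them is claimed.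

Compound 4 `COC(=O)c1ccc(-c2cnc(C(=O)CCCCCCc3ccccc3)o2)cc1` has not yet been measured. It differs from compound 3 by methoxycarbonyl in place of amino on an aromatic carbon. For the measured compounds named here, this is the same kind of change as the one from compound 1 to compound 2, but not the same: there the entering group sits ortho to a large group, here para to a large group. The step to compound 4 is expected to point the same way, yet smaller, because compound 3 already gives 90 nM. The step is estimated as a 3.6-fold lower number from compound 3 to compound 4 (0.56 log units; beyond the scatter). For compound 4 the estimate is 25 nM, expected to fall between 6 nM and 90 nM.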

Compound 4, inhibition constant: 40 nM
Compound 4: the middle estimate sits 1.6-fold (0.20 log units) below what was measured; the measured number falls inside the stated range.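

Putting methoxycarbonyl in place of amino again lowers the number in this assay, with a 2.3-fold lower number from compound 3 to compound 4 (0.35 log units; beyond the scatter), so the direction of the change carries over from the core of compound 1 to the core of compound 3. The size of the change does not carry over, and the gap between the two steps is larger than repeated measurements would explain: the same change on two cores in this assay, a 13-fold lower number (1.10 log units; beyond the scatter) from compound 1 to compound 2 and a 2.3-fold lower number (0.35 log units; beyond the scatter) from compound 3 to compound 4, 5.6-fold (0.74 log units) apart, beyond the scatter of two such steps. These two pairs show that the same swap can give clearly different gains within this series, but they do not show why, and two pairs are too few to set a rule for other cores.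

On these data alone, it remains open whether a carboxylic acid or an amide in place of the amino group would follow the methoxycarbonyl group or behave differently. As far as these compounds go, it is also open whether the swap would give a step of similar size on a compound with a shorter or longer chain between the carbonyl and the end phenyl ring.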